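Chain shortening in a chlorophenyl biguanide-type series

This account rests on a few compounds, and the source may have more. Where it says the series, first, only, none or still open, it means among the compounds named here.

Three analogues have been measured in a physicochemical assay for lipophilicity, in phosphate buffer, measured as octanol-water partition, at pH 11.5; a lower number here means a more polar compound, a higher number a more lipophilic compound. Compound 1, `CCCCCCCCOC(=N)NC(=N)Nc1ccc(Cl)cc1`, gives 5.32 in this assay. Compound 2, `CCOC(=N)NC(=N)Nc1ccc(Cl)cc1`, gives 2.32 in this assay. Compound 3, `CCCCCCCCCCNC(=N)NC(=N)Nc1ccc(Cl)cc1`, gives 6.13 in this assay, the highest of the three numbers. Compound 4, `CCCCNC(=N)NC(=N)Nc1ccc(Cl)cc1`, is not yet measured.

Going by the values given here, the one measured step within a single change is that from compound 1 to compound 2, where the change is hydrogen in place of hexyl on a saturated chain carbon, two bonds along the chain from an oxygen on an unsaturated carbon; it gave a number 3.00 log units lower from compound 1 to compound 2 (beyond the scatter).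

Compound 4 is derived from compound 3 by hydrogen in place of hexyl on a saturated chain carbon, four bonds along the chain from an amine nitrogen. This is the same kind of change as that from compound 1 to compound 2, but the place around it is not the same: in the first pair the chain carbon lies two bonds along the chain from an oxygen on an unsaturated carbon, in the second pair four bonds along the chain from an amine nitrogen. The difference between the core of compound 1 and the core of compound 3 is not broken down here; their values show that compound 3 sits higher by a margin beyond the scatter.

Among the compounds with values here, with only one measured step of this kind available, the step from compound 3 to compound 4 is expected to be of about the same size, a number 3.03 log units lower from compound 3 to compound 4 (beyond the scatter), resting on the value of compound 3, 6.13, and on the measured step from compound 1 to compound 2, a number 3.00 log units lower from compound 1 to compound 2 (beyond the scatter). Compound 4 is thus estimated to give 3.1 in this assay, with a range from 2.6 to 3.6.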

Compound 4, partition coefficient: 3.13
Beside the measured number, compound 4's estimate is 0.03 log units below it, and the stated range covers the measured number.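

In this assay, hydrogen in place of hexyl gave a number 3.00 log units lower from compound 3 to compound 4 (beyond the scatter) and, on the other core, a number 3.00 log units lower from compound 1 to compound 2 (beyond the scatter); across these two pairs the change therefore carried from the core of compound 1 to the core of compound 3 at the same size, although its place differs, two bonds along the chain from an oxygen on an unsaturated carbon in one pair and four bonds along the chain from an amine nitrogen in the other. These two pairs do not show that the step holds on any further core or for any other chain, and the remaining comparison, a number 0.81 log units higher from compound 2 to compound 4 (beyond the scatter), with butylamino in place of ethoxy, changes both the chain and the atom joining it to the carbon with a double bond to nitrogen, so the two contributions cannot be separated. Nothing available gives a reason for the match between the two hexyl steps.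

Open, as far as these compounds go, is how much of the difference between ethoxy and butylamino belongs to the chain, which a butoxy group on the same core would help to settle. Also open, from the compounds shown here alone, is whether the hexyl step keeps its size on a chain carrying a hydroxyl group or a carboxylic acid.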